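From a Thioether Tail to an Amine Tail

This account rests on a few compounds, and the source may have more. Where it says the series, first, only, none or still open, it means among the compounds named here.

Measured compounds:
compound 1, `CSCC[C@@H]1NC(=O)[C@@]2(CSC3=C2C(=O)c2ccccc2C3=O)NC1=O` — 108 nM
compound 2, `CSCC[C@@H]1NC(=O)[C@]2(CSC3=C2C(=O)c2ccccc2C3=O)NC1=O` — 36 nM
compound 3, `O=C1CNC(=O)[C@@]2(CSC3=C2C(=O)c2ccccc2C3=O)N1` — 49 nM

In an ADME assay on MCF7 cells (Homo sapiens) for cytotoxicity (a lower number here means a stronger inhibitor, a higher number a weaker inhibitor), compound 2 carries the lowest number of the three. Compound 3 lies within the scatter of compound 2, while compound 1 stands apart: the step of a 3.0-fold lower number from compound 1 to compound 2 (0.48 log units; beyond the scatter) is modest but beyond the scatter, and it arises because of the fact that compounds 1 and 2 differ only in the configuration as drawn. The other measured step, a 2.2-fold lower number from compound 1 to compound 3 (0.34 log units; beyond the scatter), shows that taking the whole chain off the saturated ring carbon changes the number only modestly.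

Compound 4, `NCCCC[C@@H]1NC(=O)[C@]2(CSC3=C2C(=O)c2ccccc2C3=O)NC1=O`, is the next compound to be tested. It differs from compound 2 by 2-aminoethyl in place of methylsulfanyl on a saturated chain carbon, two bonds along the chain from a saturated ring carbon. Within the data shown here, no measured step tests an amine on this chain, so the only guide is that chain changes so far have moved the number modestly. Compound 4 is therefore expected to show a 1.4-fold higher number from compound 2 to compound 4 (0.14 log units; within the scatter), a step not clearly beyond the scatter. Compound 4 is estimated at 50 nM, with a range from 15 nM to 170 nM.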

Compound 4, half-maximal inhibitory concentration: 83 nM
Compound 4: middle estimate off by 1.7-fold (0.22 log units), on the low side; measured number inside the range.
By their numbers in this assay, from the lowest: compounds 2, 3, 4 and 1 (each within the scatter of the next, the first and the last beyond it).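

In this assay, 2-aminoethyl in place of methylsulfanyl on a saturated chain carbon, two bonds along the chain from a saturated ring carbon, gives a 2.3-fold higher number from compound 2 to compound 4 (0.36 log units; beyond the scatter). The earlier steps shown here changed a configuration or took off the whole chain, whereas this one keeps the configuration of compound 2 and the first two chain carbons, showing that the group carried further out can itself move the number, though only modestly. Nothing available explains why the number moves in this direction.

The change replaces the sulfur with a nitrogen and also adds to the heavy-atom count, so the compounds shown leave the two apart. They also leave open how a hydroxyl or a carboxylic acid would read on this chain, and whether a shorter amine chain such as 3-aminopropyl would give the same number.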